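This account rests on a few compounds, and the source may have more. Where it says the series, first, only, none or still open, it means among the compounds named here.

Compound 2 `Cc1noc(-c2c(F)cccc2-c2ccc([C@@H](C)Nc3nccc(Cl)c3NC(=O)CC#N)cc2)n1` stands at the higher end of the two measured compounds in an in vivo ADME assay on the whole organism (strain Sprague-Dawley) for metabolic stability, with Rattus norvegicus as the target, at a dose of 2 mg/kg by the intravenous route; on this read-out lower numbers stand for a shorter-lived compound and higher numbers for a longer-lived compound: compound 2 gives 8.8 h, whereas compound 1 `COC(=O)c1ccc(Cl)cc1-c1ccc([C@@H](C)Nc2nccc(Cl)c2NC(=O)CC#N)cc1` gives 0.5 h, a gap that lies beyond the usual scatter. Compound 3 `C[C@@H](Nc1nccc(Cl)c1NC(=O)CC#N)c1ccc(-c2cccc(F)c2C#N)cc1` has not yet been measured in this assay. It differs from compound 2 in one place: cyano in place of 3-methyl-1,2,4-oxadiazol-5-yl on an aromatic carbon. Among the compounds with values here, no measured pair shows this exchange, so its direction cannot be read off the measured compounds, and the gap between compound 2 and compound 1 rests on a different change. With only that to go on, compound 3 is expected to show a moderate shortening, a 2.2-fold lower number from compound 2 to compound 3 (0.34 log units; beyond the scatter), with a wide uncertainty in either direction. Compound 3 is thus expected to give 4 h, with a range from 1.5 h to 12 h.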

Compound 3, half-life: 0.9 h
Beside the measured number, compound 3's estimate is 4.4-fold (0.65 log units) above it; measured number below the stated range.
By their numbers in this assay, from the lowest: compounds 1 and 3 (each within the scatter of the next); then compound 2.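

In this assay, within the data shown here, the exchange on this aromatic carbon, ortho to a fluoro group, gives a 9.8-fold lower number from compound 2 to compound 3 (0.99 log units; beyond the scatter) and so provides the first direct reading of cyano in place of 3-methyl-1,2,4-oxadiazol-5-yl. The long half-life of compound 2 is therefore not retained once the five-membered aromatic ring gives way to the much smaller cyano group. The other exchange, 2-cyano-3-fluorophenyl in place of 5-chloro-2-(methoxycarbonyl)phenyl, gives a 1.8-fold higher number from compound 1 to compound 3 (0.26 log units; within the scatter) and stays within the scatter, which leaves compound 2 alone apart from the other two. The data offer no explanation for the size of the step. Still open, going by these compounds, is whether a different group at this position, such as a primary carboxamide or a tetrazole, would match 3-methyl-1,2,4-oxadiazol-5-yl or fall with cyano.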